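Swapping the aryl group on the hydrazone of compound 1

The compounds below may be only part of what the source reports. "The series", "measured", "known", "first", "only" and "open" are said of these compounds alone.

Compound 1 `Cn1c(=O)c(=O)n(C2CCCC2)c2nc(N/N=C/c3ccc(S(C)(=O)=O)cc3)ncc21` carries a 4-(methylsulfonyl)phenyl group on a carbon with a double bond to nitrogen. Among the compounds with values here, in a functional assay on HCT-116 cells (Homo sapiens) for antiproliferative activity, read by MTT assay (a lower number here means a stronger inhibitor, a higher number a weaker inhibitor), compound 1 gives 86600 nM, the highest of the two numbers measured so far. Its nearest neighbour is compound 2 `Cn1c(=O)c(=O)n(C2CCCC2)c2nc(N/N=C/c3cccc(O)c3)ncc21`, which in this assay gives 37200 nM; the change a 2.3-fold lower number from compound 1 to compound 2 (0.37 log units; beyond the scatter) comes from putting a 3-hydroxyphenyl group in place of the 4-(methylsulfonyl)phenyl.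

Compound 3 `Cn1c(=O)c(=O)n(C2CCCC2)c2nc(N/N=C/c3ccccc3F)ncc21` differs from compound 1 as follows: 2-fluorophenyl in place of 4-(methylsulfonyl)phenyl on a carbon with a double bond to nitrogen. Within the data shown here, the only measured step that bears on this is the one from compound 1 to compound 2, where another aryl group replaced the same 4-(methylsulfonyl)phenyl and the number fell modestly, just beyond the scatter. A similar move is expected here, with a smaller aryl group entering again, so a modest lowering of the number, a 1.7-fold lower number from compound 1 to compound 3 (0.24 log units; within the scatter), is the expectation. Compound 3 is therefore estimated to give about 50000 nM in this assay, within a range from 20000 nM to 120000 nM.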

Compound 3, half-maximal inhibitory concentration: 20700 nM
Compound 3: middle estimate off by 2.4-fold (0.38 log units), on the high side, within the range that was stated.
By their numbers in this assay, from the lowest: compounds 3 and 2 (each within the scatter of the next); then compound 1.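

In this assay, a second aryl group in the same place again lowers the number, here as a 4.2-fold lower number from compound 1 to compound 3 (0.62 log units; beyond the scatter). Compound 1, with its 4-(methylsulfonyl)phenyl, now stands beyond the scatter from both of the others, so within this small set it is the weakest inhibitor, and that holds for two quite different replacements, 3-hydroxyphenyl and 2-fluorophenyl. Those two replacements cannot be told apart, as a 1.8-fold lower number from compound 2 to compound 3 (0.25 log units; within the scatter) shows, and nothing measured here says what lies behind any of these numbers.

From the compounds shown here alone, whether the fluorine itself contributes remains open: a plain phenyl group or a 4-fluorophenyl group on the same carbon would be needed to separate its contribution from that of the ring alone. Also open, going by these compounds, is how the number would respond to an amine or a carboxylic acid on the aromatic ring, or to a longer chain in place of that ring.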